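Ethoxy in Place of Fluoro: Expecting Compound 3

The compounds below may be only part of what the source reports. "The series", "measured", "known", "first", "only" and "open" are said of these compounds alone.

Measured so far, in a functional assay on the whole organism (integument) for inhibition, with Chilo suppressalis as the target, read by scintillation counting, with a stated time of 72 h, in the presence of a further agent that is not named here; a higher number here means a weaker inhibitor, a lower number a stronger inhibitor:
Compound 1, `COc1cccc(OC)c1C(=O)Nc1nnc(-c2ccc(Cl)cc2)s1`, gives 58.9 nM.
Compound 2, `COc1cccc(OC)c1C(=O)Nc1nnc(-c2ccc(F)cc2)s1`, gives 89.1 nM.

Within the data shown here, compound 2 has the highest of the two numbers, but its only neighbour, compound 1, sits within the scatter of it: the step of a 1.5-fold higher number from compound 1 to compound 2 (0.18 log units; within the scatter) is too small to count as a real difference.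

Compound 3, `CCOc1ccc(-c2nnc(NC(=O)c3c(OC)cccc3OC)s2)cc1`, has not yet been measured in this assay. It differs from compound 2 in one place: ethoxy in place of fluoro on an aromatic carbon. Among the measured compounds shown here, the one measured step that bears on this position, a 1.5-fold higher number from compound 1 to compound 2 (0.18 log units; within the scatter), stayed within the scatter when the group on that aromatic carbon was exchanged. On this thin basis, compound 3 is expected to stay close to compound 2 in this assay, with a 1.0-fold lower number from compound 2 to compound 3 (0.02 log units; within the scatter) expected rather than any step beyond the scatter. The estimate for compound 3 in this assay is 85 nM, with a range from 30 nM to 250 nM.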

Compound 3, half-maximal inhibitory concentration: 95.5 nM
Compound 3: the middle estimate sits 1.1-fold (0.05 log units) below what was measured; the measured number falls inside the stated range.
By their numbers in this assay, from the lowest: compounds 1, 2 and 3 (each within the scatter of the next).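

Until compound 3, this aromatic carbon had carried only the single atoms of fluoro and chloro, so ethoxy, with its 3 heavy atoms and 1 hydrogen-bond acceptor, is the first larger group shown there. In this assay, the exchange for fluoro stays within the scatter (a 1.1-fold higher number from compound 2 to compound 3 (0.03 log units; within the scatter)), and so does the exchange for chloro (a 1.6-fold higher number from compound 1 to compound 3 (0.21 log units; within the scatter)), so compounds 1, 2 and 3 cannot be told apart at this position. Nothing available explains why the three groups read alike.

Going by these compounds, whether this tolerance extends to an amine, a carboxylic acid or a longer chain such as hexyloxy remains open. The compounds shown also leave untested how much the result depends on the rest of the shared core, which is the same in all three.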